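The source may report more compounds than this note shows. Statements on the series, on what has been measured and on what is new or still open speak of the compounds shown alone.

Compound 1 `NC(=O)c1ccccc1NC(=O)COc1ccccc1` gives 57.4%
Compound 2 `Cc1ccccc1OCC(=O)Nc1ccccc1C(N)=O` gives 19.7%
Compound 3 `NC(=O)c1cc(Cl)ccc1NC(=O)COc1ccccc1` gives 87%

In a functional assay on K562 cells (Homo sapiens) for inhibition, read by trypan blue exclusion, with a stated time of 24 h, tested at 10 uM (a higher number here means more inhibition of growth at the concentration tested, a lower number less inhibition of growth), compound 3 stands highest of the three measured compounds. Compound 4 `Cc1ccccc1OCC(=O)Nc1ccc(Cl)cc1C(N)=O` differs from it in one place (methyl in place of hydrogen on an aromatic carbon) with methyl in place of hydrogen on an aromatic carbon, which turns phenyl to 2-methylphenyl. This same change has been measured once (a number 37.7 percentage points lower from compound 1 to compound 2 (beyond the scatter)) and that step was large. The other measured step (a number 29.6 percentage points higher from compound 1 to compound 3 (beyond the scatter)) added the chloro that compound 4 keeps. A single pair is thin support, so the uncertainty is wide. A large downward step is expected, and the estimated step is a number 37 percentage points lower from compound 3 to compound 4 (beyond the scatter). Compound 4 is therefore estimated at 50% (expected range 25% to 75%).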

Compound 4, percent growth inhibition at one concentration: 75.9%
Compound 4: the middle estimate sits 25.9 percentage points below what was measured; the measured number lies above the stated range.
By their numbers in this assay, from the lowest: compound 2; then compound 1; then compound 4; then compound 3.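

With the chloro present, the change from phenyl to 2-methylphenyl still lowers the number, giving a number 11.1 percentage points lower from compound 3 to compound 4 (beyond the scatter), so the direction holds on both cores but the size does not carry over: the same change on two cores in this assay, a number 37.7 percentage points lower (beyond the scatter) from compound 1 to compound 2 and a number 11.1 percentage points lower (beyond the scatter) from compound 3 to compound 4, 26.6 percentage points apart, beyond the scatter of two such steps

Read the other way, the chloro gives a number 56.2 percentage points higher from compound 2 to compound 4 (beyond the scatter), so the two changes do not simply add up: the same change on two cores in this assay, a number 29.6 percentage points higher (beyond the scatter) from compound 1 to compound 3 and a number 56.2 percentage points higher (beyond the scatter) from compound 2 to compound 4, 26.6 percentage points apart, beyond the scatter of two such steps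

Still open, as far as these compounds go, is whether an ethyl or a methoxy in place of the methyl would behave the same way, and whether a fluoro or a bromo in place of the chloro would also shrink the methyl step.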